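The source may report more compounds than this note shows. Statements on the series, on what has been measured and on what is new or still open speak of the compounds shown alone.

Measured compounds:
- compound 1, `COc1ccc(OC)c(/C=C/c2nnc(Nc3ccc(Cl)cc3)o2)c1` — "not determined" (no result reported) in a functional assay on NCI-H226 cells (Homo sapiens) for antiproliferative activity, read by sulforhodamine B assay, with a stated time of 48 h; a higher number here means that more compound is tolerated, a lower number that less compound is tolerated
- compound 2, `COc1ccc(OC)c(/C=C/C(=O)N/N=C/c2ccc(Cl)cc2)c1` — > 100000 nM

Compound 1 carries no number in this assay. For compound 2 the value of > 100000 nM is a limit of the assay and not a measured number. Of the two entries shown, one sits at this limit, as the limit of > 100000 nM in this assay, at which 1 of the 2 values shown sits, records, and the other has no result at all, so compound 2 cannot be placed against any measured neighbour in the series.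

Compound 3, `COc1ccc(OC)c(/C=C/C(=O)N/N=C/c2ccccc2)c1`, is not yet measured. It differs from compound 2 in one place: hydrogen in place of chloro on an aromatic carbon, which read one bond further out is 4-chlorophenyl to phenyl. Among the measured compounds shown here, no step between measured compounds exists here, so the change has no recorded size in this assay.

The expected step that the limit leaves unreadable from compound 2 to compound 3 is none beyond the scatter, the reasoning resting on compound 2 sitting at > 100000 nM. Compound 3 is therefore estimated at 120000 nM, with a range from 40000 nM to 400000 nM, and most likely only a limit will be reported again.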

Compound 3, concentration lethal to 50% of the cells: > 100000 nM
Compound 3: no number, only a limit; the forecaster's own chance of this, stated with the estimate: 80%; the middle value is on the limit's open side.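

No step can be read from compound 2 to compound 3, since the entries for both in this assay are limits and not numbers: the limit of > 100000 nM in this assay, at which 2 of the 3 values shown sit.

The compounds shown leave open whether 4-chlorophenyl and phenyl differ at all in this assay, and where any compound of this series would fall as a single number there.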